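The source may hold more compounds than are shown below. What is called first, only, known or untested is meant among the compounds shown, and "the series" means these compounds.

Measured compounds in a functional assay on SW-620 cells (Homo sapiens) for cytotoxicity, read by MTT assay, with a stated time of 48 h; a higher number here means a weaker inhibitor, a lower number a stronger inhibitor:
compound 1 `CCCCCCCCCCCCCCCCCCNC(=O)[C@@H](NC(=O)c1ccccc1)[C@@H](C)O` gives 200000 nM.
compound 2 `CCCCCCCCCCCCCCCCCCNC(=O)[C@@H](NC(=O)c1ccco1)[C@@H](C)O` gives only the limit > 200000 nM.
compound 3 `CCCCCCCCCCCCCCCCCCNC(=O)[C@@H](NC(=O)c1cc2ccccc2o1)[C@@H](C)O` gives only the limit > 200000 nM.

Going by the values given here, compound 3 thus stands at the limit of > 200000 nM in this assay, at which 2 of the 3 values shown sit, with no number of its own; the one number belongs to compound 1. The next step, to compound 4 `CCCCCCCCCCCCCCCCCCNC(=O)[C@@H](NC(=O)/C=C/c1ccccc1)[C@@H](C)O`, is 2-phenylethenyl in place of 1-benzofuran-2-yl on a carbonyl carbon. Among the compounds with values here, no measured step covers this change. Within the data shown here, the measured steps read a number no lower from compound 1 to compound 2 (the limit leaves the size open), a number no lower from compound 1 to compound 3 (the limit leaves the size open) and a step that the two limits leave unreadable from compound 2 to compound 3, none of them sized, so they give no direction for the step to compound 4. With two of three values at the limit and the third at the same number, no step beyond the scatter is expected: a number no higher from compound 3 to compound 4 (the limit leaves the size open). Compound 4 is therefore estimated at 200000 nM, within 80000 nM to 500000 nM, with a fair chance that this assay again reports only a limit.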

Compound 4, half-maximal inhibitory concentration: 200000 nM
Beside the measured number, compound 4's estimate shows no gap at the digits printed; low and high end bracket the measured number.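

In this assay, 2-phenylethenyl in place of phenyl on a carbonyl carbon gives no change at the digits printed from compound 1 to compound 4 (within the scatter). This position therefore now has a second readable number, and phenyl and 2-phenylethenyl do not separate here. 2-phenylethenyl in place of 1-benzofuran-2-yl on a carbonyl carbon gives a number no higher from compound 3 to compound 4 (the limit leaves the size open), and 2-phenylethenyl in place of furan-2-yl on a carbonyl carbon gives a number no higher from compound 2 to compound 4 (the limit leaves the size open). Neither of these two steps can be sized, as each starts from a limit: the limit of > 200000 nM in this assay, at which 2 of the 4 values shown sit.

From the compounds shown here alone, whether any group on this carbonyl carbon moves the number beyond the scatter stays open. So does the effect of an amine or a carboxylic acid on the phenyl ring, or of a shorter chain in place of the long alkyl chain.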